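The source may hold more compounds than are shown below. What is called first, only, known or untested is meant among the compounds shown, and "the series" means these compounds.

Measured so far:
compound 1 `COc1ccc(C#N)cc1S(=O)(=O)Nc1cnc2ccccc2c1`, 38 nM
compound 2 `COc1ccc(Cl)cc1S(=O)(=O)Nc1cncc(C(N)=O)c1`, 16 nM
compound 3 `COc1ccc(Cl)cc1S(=O)(=O)Nc1cncc(C(=O)O)c1`, 134 nM

All three values come from an assay on isolated protein for inhibition of alkaline phosphatase, tissue-nonspecific isozyme (Homo sapiens); on this read-out lower numbers stand for stronger inhibition and higher numbers for weaker inhibition. Compound 1 stands second highest of the three numbers; compound 2 gives the nearest value and compound 3 the furthest, both beyond the scatter. Among the measured compounds shown here, the only single-point step measured so far is an 8.4-fold higher number from compound 2 to compound 3 (0.92 log units; beyond the scatter), a change on a carbonyl carbon in a different core, with no bearing on the present change.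

Compound 4 `COc1ccc(C(F)(F)F)cc1S(=O)(=O)Nc1cnc2ccccc2c1` differs from compound 1 by trifluoromethyl in place of cyano on an aromatic carbon. For the measured compounds named here, no measured step touches this position or this exchange, so nothing in the set argues for a step beyond the scatter in this assay in either direction. The estimate for compound 4 is therefore 40 nM, expected between 15 nM and 110 nM, which means an expected step of a 1.1-fold higher number from compound 1 to compound 4 (0.02 log units; within the scatter).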

Compound 4, half-maximal inhibitory concentration: 26 nM
Beside the measured number, compound 4's estimate is 1.5-fold (0.19 log units) above it; measured number inside the range.
By their numbers in this assay, from the lowest: compounds 2, 4 and 1 (each within the scatter of the next, the first and the last beyond it); then compound 3.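

In this assay, trifluoromethyl in place of cyano on this aromatic carbon, para to a methoxy group, gives a 1.5-fold lower number from compound 1 to compound 4 (0.16 log units; within the scatter) on the core of compound 1. This position therefore takes either group without a step beyond the scatter, although the exchange goes from 2 heavy atoms and 1 hydrogen-bond acceptor to 4 heavy atoms and 0 hydrogen-bond acceptors. No measurement at hand offers an explanation for this result. As far as these compounds go, an amine or a longer chain on this carbon remains open, as does whether the same exchange gives a similar step on the core of compound 2.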